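This account rests on a few compounds, and the source may have more. Where it says the series, first, only, none or still open, it means among the compounds named here.

Of the compounds shown here, three built on one shared core have been measured. Compound 1 `N#Cc1cccnc1N1CCc2oc(-c3ccccc3)nc2C1` gives 1200 nM in an assay on CHO cells for inhibition of metabotropic glutamate receptor 5 (Homo sapiens); on this read-out higher numbers stand for weaker inhibition and lower numbers for stronger inhibition. Compound 2 `N#Cc1cccnc1N1CCc2oc(-c3ccccn3)nc2C1` gives 110 nM, a step of an 11-fold lower number from compound 1 to compound 2 (1.04 log units; beyond the scatter). Compound 3 `c1ccc(N2CCc3oc(-c4ccccn4)nc3C2)cc1` gives 330 nM, the second highest of the three numbers: compound 2 lies lower and compound 1 lies higher. Compound 4 `N#Cc1cccc(N2CCc3oc(-c4ccccn4)nc3C2)c1` is the next compound, made from compound 3 by one change: cyano in place of hydrogen on an aromatic carbon. Among the compounds with values here, no measured step covers this change directly; the single measured step concerns a different ring, and compound 2 and compound 3 differ in two places at once, so their values alone say little about a cyano group. Compound 4 is therefore expected to move only modestly, a 1.7-fold lower number from compound 3 to compound 4 (0.22 log units; within the scatter). The estimate for compound 4 is 200 nM, ranging from 60 nM to 700 nM.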

Compound 4, half-maximal inhibitory concentration: 60 nM
Compound 4: the middle estimate sits 3.3-fold (0.52 log units) above what was measured; the range from low to high includes it.
By their numbers in this assay, from the lowest: compounds 4 and 2 (each within the scatter of the next); then compound 3; then compound 1.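

Cyano in place of hydrogen, meta to a large group, brings a 5.5-fold lower number from compound 3 to compound 4 (0.74 log units; beyond the scatter) in this assay and thus stronger inhibition. The earlier step concerned a different ring, so this is the only measured sign that a small change on this six-membered aromatic ring of carbon only can also shift the number. Nothing measured here gives a reason for this gain.

The compounds shown leave open whether the gain belongs to cyano itself or would also come with another group there, such as an amine or a carboxylic acid. They also leave open how cyano would behave at other places on this ring.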